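Replacing 1,2-dihydroxyethyl with carbamoyl in compound 3

This account rests on a few compounds, and the source may have more. Where it says the series, first, only, none or still open, it means among the compounds named here.

Compound 1 `Cn1ncc(Cl)c1-c1cc(C(=O)N[C@@H]2CN[C@H](CCNS(C)(=O)=O)C[C@H]2c2ccc(F)c(F)c2)oc1Cl` gives 1530 nM
Compound 2 `Cn1ncc(Cl)c1-c1cc(C(=O)N[C@@H]2CN[C@H](CC(O)CO)C[C@H]2c2ccc(F)c(F)c2)oc1Cl` gives 690 nM
Compound 3 `Cn1ncc(Cl)c1-c1cc(C(=O)N[C@@H]2CN[C@H](CC(O)CO)C[C@H]2c2ccc(Cl)c(Cl)c2)oc1Cl` gives 1610 nM

All three numbers come from a functional assay on OVCAR-8 cells (Homo sapiens) for antiproliferative activity (on this read-out higher numbers stand for weaker inhibition and lower numbers for stronger inhibition), and all three compounds share one core. Compound 3 lies within the scatter of compound 1, and only compound 2 stands apart from them. Changing the aryl group gave a clear but modest shift (a 2.3-fold higher number from compound 2 to compound 3 (0.37 log units; beyond the scatter)).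

Compound 4 `Cn1ncc(Cl)c1-c1cc(C(=O)N[C@@H]2CN[C@H](CC(N)=O)C[C@H]2c2ccc(Cl)c(Cl)c2)oc1Cl` keeps the 3,4-dichlorophenyl of compound 3 but has carbamoyl in place of 1,2-dihydroxyethyl on a saturated chain carbon bound to a saturated ring carbon. The aryl step does not touch this place. Among the compounds with values here, the one measured step that does is a different swap, made with 3,4-difluorophenyl (a 2.2-fold lower number from compound 1 to compound 2 (0.35 log units; beyond the scatter)), and it too was modest. Within the data shown here, no measured compound carries carbamoyl, so the data give no firm direction.

In this assay the expected result is therefore a 1.2-fold lower number from compound 3 to compound 4 (0.06 log units; within the scatter) and no clear change either way. Compound 4 is estimated at 1400 nM with an expected range from 600 nM to 3300 nM once measured.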

Compound 4, half-maximal inhibitory concentration: 1000 nM
Compound 4: middle estimate off by 1.4-fold (0.15 log units), on the high side, within the range that was stated.
By their numbers in this assay, from the lowest: compounds 2, 4, 1 and 3 (each within the scatter of the next, the first and the last beyond it).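

In this assay, putting carbamoyl in place of 1,2-dihydroxyethyl gives a 1.6-fold lower number from compound 3 to compound 4 (0.21 log units; within the scatter) in the 3,4-dichlorophenyl series. So on this saturated chain carbon bound to a saturated ring carbon, the smaller carbamoyl can stand in for 1,2-dihydroxyethyl without a change beyond the usual scatter, whereas the only other step at this place, a 2.2-fold lower number from compound 1 to compound 2 (0.35 log units; beyond the scatter), carries 3,4-difluorophenyl and does lie beyond it. No measurement available here explains why these two groups read alike.

As far as these compounds go, whether carbamoyl would also match 1,2-dihydroxyethyl alongside the 3,4-difluorophenyl of compound 2 stays open. So does the outcome with a primary amine, a carboxylic acid or a longer chain at this place.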